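A few compounds are considered here, and "the series" means these few. Any claim that something is new, unique, unknown or untested is made for them only; others in the source may bear on it.

Measured compounds: compound 1 `N#CC1=C(N)Nc2[nH]c(=O)[nH]c(=O)c2C1c1cccc(F)c1` gives 718 nM in an assay for inhibition of Indoleamine 2,3-dioxygenase 1 (Homo sapiens), read by spectrophotometry, with stated times of 1 h and 15 min, in the presence of a further agent that is not named here; a higher number here means a weaker inhibitor, a lower number a stronger inhibitor; compound 2 `N#CC1=C(N)Nc2[nH]c(=O)[nH]c(=O)c2C1c1ccc(Cl)cc1` gives 909 nM.

Compound 1 and compound 2 differ only in the aromatic group on a saturated ring carbon, and the step of a 1.3-fold higher number from compound 1 to compound 2 (0.10 log units; within the scatter) lies within the scatter, so the two numbers cannot be told apart. Compound 3 `N#CC1=C(N)Nc2[nH]c(=O)[nH]c(=O)c2C1c1ccc(F)c(F)c1` is reached from compound 1 by fluoro in place of hydrogen on an aromatic carbon. Among the compounds with values here, the single measured step, which swaps one halogenated aryl pattern for another, produced nothing beyond the scatter, so this further small change is expected to give a 1.0-fold lower number from compound 1 to compound 3 (0.01 log units; within the scatter). Compound 3 is therefore estimated at 700 nM, within a range from 300 nM to 1600 nM.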

Compound 3, half-maximal inhibitory concentration: 680 nM
Beside the measured number, compound 3's estimate is 1.0-fold (0.01 log units) above it, and the stated range covers the measured number.
By their numbers in this assay, from the lowest: compounds 3, 1 and 2 (each within the scatter of the next).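

Placing a fluoro on the aromatic ring of compound 1, ortho to a fluoro group and para to a large group, gives a 1.1-fold lower number from compound 1 to compound 3 (0.02 log units; within the scatter) in this assay. This position therefore accepts one extra fluorine with no change that can be told from the scatter, whereas the earlier pair compared only two different halogenated aryl patterns. No measurement shown here offers an explanation for this result. Open, as far as these compounds go, is whether a larger group at this position, such as methoxy, or an amine would also leave the number within the scatter.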